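The compounds below may be only part of what the source reports. "The series", "measured", "known", "first", "only" and "open" are said of these compounds alone.

Measured compounds in a functional assay on MCF7 cells (Homo sapiens) for inhibition, read by MTT assay, with a stated time of 72 h; a higher number here means a weaker inhibitor, a lower number a stronger inhibitor:
compound 1 `Cc1cc(Nc2cc(-c3ccccc3)[nH]n2)n2nc(SCc3cccc4ccccc34)nc2n1`: 7560 nM
compound 2 `CCCSc1nc2nc(C)cc(Nc3cc(-c4ccccc4)[nH]n3)n2n1`: a limit of the assay, > 50000 nM
compound 3 `Cc1cc(Nc2cc(-c3ccccc3)[nH]n2)n2nc(SCc3ccc(Br)cc3)nc2n1`: 2720 nM

Compound 3 gives the lowest of the two numbers shown; the nearest is compound 1, with a 2.8-fold lower number from compound 1 to compound 3 (0.44 log units; beyond the scatter).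

Compound 4 `C#CCSc1nc2nc(C)cc(Nc3cc(-c4ccccc4)[nH]n3)n2n1` differs from compound 3 in one place: ethynyl in place of 4-bromophenyl on a saturated chain carbon bound to a sulfur. Going by the values given here, two measured steps bear on this. Replacing the six-membered aromatic ring of carbon only by a short chain has been seen once, as an at least 6.6-fold higher number from compound 1 to compound 2 (0.82 log units; beyond the scatter), and the reverse change as an at least 18-fold lower number from compound 2 to compound 3 (1.26 log units; beyond the scatter), where compound 2 sits at the limit of > 50000 nM in this assay, at which 1 of the 3 values shown sits. Both point the same way: loss of the ring on the saturated chain carbon bound to a sulfur raises the number strongly. For compound 4 a large rise in this assay is therefore expected, an 11-fold higher number from compound 3 to compound 4 (1.04 log units; beyond the scatter), with a real chance that only a limit is reported. The estimate for compound 4 is 30000 nM, within 8000 nM to 100000 nM.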

Compound 4, half-maximal inhibitory concentration: 21800 nM
For compound 4 the middle estimate is 1.4-fold (0.14 log units) above the measured one; the measured number falls inside the stated range.
By their numbers in this assay, from the lowest: compound 3; then compound 1; then compound 4. At a limit, above all of these: compound 2.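

In this assay, a short group on the saturated chain carbon bound to a sulfur need not end at a limit: ethynyl in place of ethyl gives an at least 2.2-fold lower number from compound 2 to compound 4 (0.36 log units; beyond the scatter), read against a limit and not a number: the limit of > 50000 nM in this assay, at which 1 of the 4 values shown sits. Removing the ring remains costly, with an 8.0-fold higher number from compound 3 to compound 4 (0.90 log units; beyond the scatter), while the change from naphthalen-1-yl gives a smaller 2.9-fold higher number from compound 1 to compound 4 (0.46 log units; beyond the scatter). An aromatic ring at this position is therefore not required for a measurable value.

On these data alone, how much of the difference from ethyl belongs to the triple bond stays open. A longer chain, an amine or a carboxylic acid at this position remains unplaced in this order.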